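A few compounds are considered here, and "the series" means these few. Any claim that something is new, unique, unknown or untested is made for them only; others in the source may bear on it.

Measured so far in an assay on L cells for inhibition of Protein-serine O-palmitoleoyltransferase porcupine (Mus musculus), read by reporter gene assay, with a stated time of 24 h; a higher number here means that more compound is needed for the effect, a lower number that less compound is needed:

compound 1, `COc1ccc(-n2nc(C(=O)NCC(=O)Nc3nc4ccc(C)cc4s3)c3ccccc3c2=O)cc1`, gives 25 nM;
compound 2, `COc1ccc(-n2nc(C(=O)NCC(=O)Nc3nc4ccc(OC)cc4s3)c3ccccc3c2=O)cc1`, gives 60 nM;
compound 3, `COc1ccc2nc(NC(=O)CSc3nc4c(c(=O)n3-c3ccccc3OC)SCC4)sc2c1`, gives 50 nM.

Compounds 1 and 2 share one core and differ in a single group on the benzothiazole part: methyl in place of methoxy on an aromatic carbon. That exchange brought a 2.4-fold lower number from compound 2 to compound 1 (0.38 log units; beyond the scatter), a modest step but beyond the usual scatter. Compound 3 carries a different core, and the difference between its core and that of compound 2 is not broken down here; its value sits within the scatter of the value of compound 2, so no order between them can be read. Compound 4, `COc1ccccc1-n1c(SCC(=O)Nc2nc3ccc(C)cc3s2)nc2c(c1=O)SCC2`, is not yet measured. It stands to compound 3 as compound 1 stands to compound 2: methyl in place of methoxy on an aromatic carbon. The surroundings of the changed carbon are described in the same words for both pairs, so this is the same change on a second core. Resting on the step seen from compound 2 to compound 1, compound 4 is expected to show a 2.3-fold lower number from compound 3 to compound 4 (0.36 log units; beyond the scatter), and its value in this assay is estimated at 22 nM, between 10 nM and 50 nM.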

Compound 4, half-maximal effective concentration: 25 nM
Compound 4: middle estimate off by 1.1-fold (0.06 log units), on the low side, and the stated range covers the measured number.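

In this assay, putting methyl in place of methoxy on the second core gives a 2.0-fold lower number from compound 3 to compound 4 (0.30 log units; within the scatter), so this step alone does not separate compound 3 from compound 4. Set beside the step on the first core, it shows that the change has about the same size on both cores, with no difference between the two steps that can be told from noise: the same change on two cores in this assay, a 2.4-fold lower number (0.38 log units; beyond the scatter) from compound 2 to compound 1 and a 2.0-fold lower number (0.30 log units; within the scatter) from compound 3 to compound 4, 1.2-fold (0.08 log units) apart, within the scatter of two such steps. For the compounds shown here, this agreement suggests that the effect of the change carried over from one core to the other, but it rests on only two pairs, one of which stays within the scatter, and it neither establishes a rule for other cores nor explains why the numbers behave this way.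

The compounds shown leave open whether other groups on the same aromatic carbon, such as a chlorine atom, a nitrile or an amine, would behave alike on both cores. They also leave open whether the step between methoxy and methyl would keep its size on a third core.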